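The compounds below may be only part of what the source reports. "The series", "measured", "known", "first", "only" and "open" are said of these compounds alone.

Measured so far in a functional assay on HEL cells (Homo sapiens), read by microscopy; a lower number here means that less compound is tolerated, a higher number that more compound is tolerated:

compound 1, `CCCCCCCCc1cc2cn(COCCO)c(O)nc-2n1`, gives 80000 nM
compound 2, `CCCCCCCCCCc1cc2cn(COCCO)c(=O)nc2o1`, gives 400000 nM
compound 3, `CCCCCCc1cc2cn(COCCO)c(O)nc-2n1`, gives > 400000 nM, which is a limit of the assay and not a number

Compound 1 and compound 3 share one core and differ only by hydrogen in place of ethyl on a saturated chain carbon, six bonds along the chain from an aromatic carbon. This change gave an at least 5.0-fold higher number from compound 1 to compound 3 (0.69 log units; beyond the scatter), the step resting on (the limit of > 400000 nM in this assay, at which 1 of the 3 values shown sits). Compound 2 has the other core of the series; the difference between the two cores is not broken down here, and within this assay compound 2 stands higher than compound 1.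

Compound 4, `CCCCCCCCc1cc2cn(COCCO)c(=O)nc2o1`, is not yet measured. It differs from compound 2 by hydrogen in place of ethyl on a saturated chain carbon, eight bonds along the chain from an aromatic carbon. This is the same kind of change as from compound 1 to compound 3, not the same one: there the place is six bonds along the chain from an aromatic carbon, here it is eight bonds along the chain from an aromatic carbon.

Beside the earlier step, a step of a 1.8-fold higher number from compound 2 to compound 4 (0.24 log units; within the scatter) is expected, since compound 2 already sits at 400000 nM and the shorter chain raised the number in the first pair. The estimate for compound 4 is 700000 nM.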

Compound 4, minimum cytotoxic concentration: >= 80000 nM
Compound 4 gave a limit, no number; the forecaster's own chance of this, stated with the estimate: 60%; the middle value is on the limit's open side.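

In this assay compound 4 gives >= 80000 nM as a limit of the assay and not a number. No step from compound 2 to compound 4 can be read: the limit of >= 80000 nM in this assay, at which 1 of the 4 values shown sits.

The compounds shown leave open whether hydrogen in place of ethyl, on the core of compound 2, changes the minimum cytotoxic concentration as it does on the core of compound 1.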